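Methoxy for Methyl on the Shared Core

The compounds below may be only part of what the source reports. "The series", "measured", "known", "first", "only" and "open" are said of these compounds alone.

Compound 1 `Cc1ccc2c(c1)/C(=C1/S/C(=N/c3ccc(S(N)(=O)=O)cc3)NC1=O)C(=O)N2` gives 174000 nM in a functional assay on Caco-2 cells (Homo sapiens) for antiproliferative activity, read by MTT assay; a lower number here means a stronger inhibitor, a higher number a weaker inhibitor.
Compound 2 `Cc1cc(C)c2c(c1)/C(=C1/S/C(=N/c3ccc(S(N)(=O)=O)cc3)NC1=O)C(=O)N2` gives 146000 nM in this assay.

Among the compounds with values here, of the two numbers measured, compound 1 has the highest, with compound 2 as its only neighbour. The two compounds differ by a methyl in place of hydrogen on an aromatic carbon, and that change produced a 1.2-fold lower number from compound 1 to compound 2 (0.08 log units; within the scatter), so within this pair the extra methyl left the number essentially where it was.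

Compound 3 `COc1ccc2c(c1)/C(=C1/S/C(=N/c3ccc(S(N)(=O)=O)cc3)NC1=O)C(=O)N2` is the next compound in line. Relative to compound 1 it carries methoxy in place of methyl on an aromatic carbon.

Within the data shown here, no measured step exchanges a methyl for a methoxy, so nothing here speaks directly to this change. Among the measured compounds shown here, the only step on this core, a 1.2-fold lower number from compound 1 to compound 2 (0.08 log units; within the scatter), shows that a small group added on an aromatic carbon of the shared core did not move the number beyond the scatter. On that thin basis compound 3 is expected to show no step beyond the scatter, an expected 1.1-fold lower number from compound 1 to compound 3 (0.04 log units; within the scatter). In this assay compound 3 is therefore estimated at 160000 nM, with a likely range from 60000 nM to 400000 nM.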

Compound 3, half-maximal inhibitory concentration: 98300 nM
Estimate against measurement, compound 3: 1.6-fold (0.21 log units) above; the measured number falls inside the stated range.
By their numbers in this assay, from the lowest: compounds 3, 2 and 1 (each within the scatter of the next).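

In this assay, within the data shown here, the exchange of methyl for methoxy on this aromatic carbon, meta to a fused ring and para to a fused ring, gave a 1.8-fold lower number from compound 1 to compound 3 (0.25 log units; within the scatter) and so provides the first direct reading of this change on the shared core. The earlier step showed only that an added methyl left the number within the scatter, whereas this one shows the same for a methoxy, which brings an oxygen and a hydrogen-bond acceptor that the methyl lacks. No accompanying measurement bears on this result, so it stands as a bare comparison of two numbers.

What the compounds shown leave open is whether any group at this position can move the number beyond the scatter, since an amine, a carboxylic acid, a chlorine atom and a longer chain such as ethoxy do not appear among them. With all three compounds lying within the scatter of their neighbours, they also leave open which part of the structure, if any, governs the number in this assay at all.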